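Tolerance on Dog Kidney Cells: Methyl to Ethyl on the Core

A few compounds are considered here, and "the series" means these few. Any claim that something is new, unique, unknown or untested is made for them only; others in the source may bear on it.

Compound 1 `CCc1ccc2[nH]c(=O)c(CN(CCCO)Cc3ccc(C(C)(C)C)cc3)cc2c1` was examined in a toxicity assay on MDCK cells (Canis lupus familiaris) for cytotoxicity, read by crystal violet staining, with a stated time of 48 h; a lower number here means that less compound is tolerated, a higher number that more compound is tolerated. In this assay compound 1 is reported only as a limit, > 10000 nM. Compound 2 `Cc1ccc2[nH]c(=O)c(CN(Cc3ccc(OC(F)F)cc3)Cc3ccc(C(C)(C)C)cc3)cc2c1` was examined the same way. In this assay compound 2 likewise gives only a limit, > 5000 nM. Both results therefore sit at the limit of the assay the limit of > 5000 nM in this assay, at which 1 of the 2 values shown sits (the limit of > 10000 nM in this assay, at which 1 of the 2 values shown sits), so no number places compound 2 anywhere within the scale; it is known only that it is tolerated up to the stated concentration.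

Compound 3 `CCc1ccc2[nH]c(=O)c(CN(Cc3ccc(OC(F)F)cc3)Cc3ccc(C(C)(C)C)cc3)cc2c1` has not yet been measured. It differs from compound 2 by methyl in place of hydrogen on a saturated chain carbon bound to an aromatic carbon. For this change the step that the limit leaves unreadable from compound 2 to compound 3 is expected to stay within the scatter, with no direction favoured. For compound 3 a value of about 10000 nM is estimated, lying between 4000 nM and 30000 nM, most probably reported again as a limit.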

Compound 3, half-maximal cytotoxic concentration: > 5000 nM
Compound 3 gave a limit, no number; the forecaster's own chance of this, stated with the estimate: 85%; the middle value lies beyond the limit too.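

In this assay, going by these compounds alone, the results for compound 1, compound 2 and compound 3 are all limits and not numbers, so no step among them can be read. The compounds shown leave open at what concentration any of them becomes cytotoxic, and whether methyl to ethyl alters tolerance at all.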